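Fluorine on the Pendant Phenyl: What Stability Remains

This account rests on a few compounds, and the source may have more. Where it says the series, first, only, none or still open, it means among the compounds named here.

Compound 2 `Cc1noc(C)c1[C@@H]1C[C@@](C)(c2ccc(F)cc2)N=C(N)S1` is the most stable of the three measured compounds: in an ADME assay on microsomes from liver (Mus musculus) for metabolic stability, with a stated time of 10 min, tested at 0.5 uM (a lower number here means that less of the compound is left, a higher number that more of the compound is left), compound 2 gives 90%. Compound 1 `Cc1noc(C)c1[C@@H]1C[C@@](C)(c2ccc(F)cc2F)N=C(N)S1` differs from it by fluoro in place of hydrogen on an aromatic carbon, and in this assay compound 1 gives 72%; the step is a number 18 percentage points lower from compound 2 to compound 1 (beyond the scatter). Compound 3 `Cc1onc(-c2ccccc2)c1[C@@H]1C[C@@](C)(c2ccc(F)cc2F)N=C(N)S1` gives 12% in this assay, and the step is a number 60 percentage points lower from compound 1 to compound 3 (beyond the scatter). The difference between the cores of compound 2 and compound 3 is not broken down here.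

Compound 4 `Cc1onc(-c2ccc(F)cc2)c1[C@@H]1C[C@@](C)(c2ccc(F)cc2F)N=C(N)S1` differs from compound 3 by fluoro in place of hydrogen on an aromatic carbon. This is the same kind of change as that between compound 2 and compound 1, though not the same: there the place was ortho to a large group and meta to a fluoro group, here it is para to a large group. The earlier step was a number 18 percentage points lower from compound 2 to compound 1 (beyond the scatter). Compound 3 starts from 12%, so little room remains, and the step is expected to be a number 4 percentage points lower from compound 3 to compound 4 (within the scatter). Compound 4 is therefore estimated at 8%, likely between 3% and 18%.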

Compound 4, percent of the compound remaining: 23%
Beside the measured number, compound 4's estimate is 15 percentage points below it; the measured number lies above the stated range.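

In this assay, fluoro in place of hydrogen on an aromatic carbon keeps neither its size nor its direction when carried from one core to the other: the same change on two cores in this assay, a number 18 percentage points lower (beyond the scatter) from compound 2 to compound 1 and a number 11 percentage points higher (beyond the scatter) from compound 3 to compound 4, 29 percentage points apart, beyond the scatter of two such steps The new step, a number 11 percentage points higher from compound 3 to compound 4 (beyond the scatter), recovers only a small part of what is lost when the 4-fluorophenyl group stands in place of methyl, a change that still reads a number 49 percentage points lower from compound 1 to compound 4 (beyond the scatter). This does not show why the two steps differ: the fluoro group enters at a different place in each step and the cores differ too, and a single pair on each core cannot tell these two differences apart.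

Going by these compounds, it remains open whether a chloro group or a methoxy group, placed para to a large group on the phenyl ring of compound 3, would move the number as fluoro does. Also open, on these data alone, is whether an ethyl group in place of that phenyl ring would keep more of the stability of compound 1.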